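The compounds below may be only part of what the source reports. "The series", "measured", "known", "first", "only" and "open" are said of these compounds alone.

Three compounds with a shared core have been run in an assay for inhibition of Indoleamine 2,3-dioxygenase 1 (Homo sapiens), read by spectrophotometry, with a stated time of 180 min, tested at 10 uM; on this read-out higher numbers stand for a stronger effect at the one concentration tested and lower numbers for a weaker effect. Compound 1 `O=C(O)c1cccc(CNc2cc(Br)cc3[nH]ncc23)c1` gives 21% in this assay. Compound 2 `Cc1ccc(CNc2cc(Br)cc3[nH]ncc23)cc1` gives 20% in this assay. Compound 3 `O=C(O)c1ccc(COc2cc(Br)cc3[nH]ncc23)cc1` gives 18% in this assay. On these three numbers compound 2 sits between the other two: the gap to compound 1 and the gap to compound 3 are both within the usual scatter, so the three readings cannot be told apart and no order among them is claimed.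

Compound 4 `Clc1ccc(CNc2cc(Br)cc3[nH]ncc23)cc1` has not yet been measured. It differs from compound 2 by chloro in place of methyl on an aromatic carbon.

The three measured compounds carry quite different groups on the outer ring and still return much the same reading, so no step beyond the scatter is expected in this assay from a single change of this kind. The step from compound 2 to compound 4 is estimated at no change at the digits printed from compound 2 to compound 4 (within the scatter), in effect none. For compound 4 the expected reading in this assay is 20%, within a range from 8% to 32%.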

Compound 4, a percentage reported as inhibition, at one concentration (the size of the read-out at that concentration, not a potency): 42%
Beside the measured number, compound 4's estimate is 22 percentage points below it; the whole stated range lies below it.
By their numbers in this assay, from the lowest: compounds 3, 2 and 1 (each within the scatter of the next); then compound 4.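

In this assay, for the compounds shown here, this place on the six-membered aromatic ring of carbon only, para to a large group, is the first to give a readable single change: chloro in place of methyl gives a number 22 percentage points higher from compound 2 to compound 4 (beyond the scatter). The earlier compounds shown here differ from one another in more than one place, so their closely matched readings said nothing about this position taken alone. The two groups match in the counts given, each with one heavy atom, no hydrogen-bond donors or acceptors and no net charge, and nothing at hand accounts for the step.

Open, from the compounds shown here alone, is whether bromo, trifluoromethyl or an amine at this same place would read like chloro or like methyl. Also open, going by these compounds, is whether chloro gives a similar step with the linker of compound 3.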